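Trimming the Chain Once More

The source may hold more compounds than are shown below. What is called first, only, known or untested is meant among the compounds shown, and "the series" means these compounds.

In a functional assay on SK-BR-3 cells (Homo sapiens) for antiproliferative activity (on this read-out lower numbers stand for stronger inhibition and higher numbers for weaker inhibition), compound 1 (`CCCCCCC(=O)Nc1cc2ccc(O[C@@H]3OC(C)(C)[C@H](OC)[C@@H](O)[C@H]3O)c(C)c2oc1=O`) gives 58300 nM, and compound 2 (`CCCCC(=O)Nc1cc2ccc(O[C@@H]3OC(C)(C)[C@H](OC)[C@@H](O)[C@H]3O)c(C)c2oc1=O`) gives 118000 nM. Within the data shown here, compound 2 therefore holds the higher of the only two numbers available and is the weaker inhibitor of the pair. Compound 3 (`CCCC(=O)Nc1cc2ccc(O[C@@H]3OC(C)(C)[C@H](OC)[C@@H](O)[C@H]3O)c(C)c2oc1=O`) has not yet been measured. It differs from compound 2 as follows: hydrogen in place of methyl on a saturated chain carbon, three bonds along the chain from a carbonyl carbon. In words, it carries hydrogen in place of methyl on a saturated chain carbon, three bonds along the chain from a carbonyl carbon.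

Among the measured compounds shown here, only one measured step bears on this change: a 2.0-fold higher number from compound 1 to compound 2 (0.31 log units; beyond the scatter). That modest step, just beyond the scatter, put hydrogen in place of ethyl on the same chain. One step does not establish a trend, but it suggests a further move towards a higher number in this assay. With methyl rather than ethyl leaving, the move is expected to be of similar or smaller size, and it may not clear the scatter. The expected step is a 1.4-fold higher number from compound 2 to compound 3 (0.15 log units; within the scatter). For compound 3 the estimated value is 165000 nM, with an expected range from 90000 nM to 300000 nM.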

Compound 3, half-maximal inhibitory concentration: 313000 nM
The estimate for compound 3 lay 1.9-fold (0.28 log units) below the measured number, outside the stated range (above it).
By their numbers in this assay, from the lowest: compound 1; then compound 2; then compound 3.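

Removing one methyl from this saturated chain carbon, three bonds along the chain from a carbonyl carbon, was enough by itself to give a step beyond the scatter in this assay (a 2.7-fold higher number from compound 2 to compound 3 (0.42 log units; beyond the scatter)). Read as butyl to propyl, this change shows that the rise seen on the first trimming of the chain did not stop there: it repeated in the same direction, and the two shortenings together add up to a wider separation (a 5.4-fold higher number from compound 1 to compound 3 (0.73 log units; beyond the scatter)). Across these three compounds the number rises each time the chain is shortened and none of them goes against that order, but nothing measured here explains why the number changes with chain length.

The compounds shown leave open whether the same direction would hold for a still shorter ethyl or methyl chain, and whether a longer chain than that of compound 1 would bring the number lower. They also leave open how a chain carrying an amine or a carboxylic acid would compare with these plain carbon chains.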